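This account rests on a few compounds, and the source may have more. Where it says the series, first, only, none or still open, it means among the compounds named here.

In a functional assay on HepG2 cells (Homo sapiens) for cytotoxicity, with a stated time of 72 h (a lower number here means that less compound is needed, a higher number that more compound is needed for the effect), compound 1 (`C=C[C@@](C)(/C=C/c1ccc(O)cc1)CC/C=C(\C)C=O`) gives > 52000 nM as a limit of the assay and not a number. Compound 2 (`C=C[C@@](C)(/C=C/c1ccc(O)cc1)CC/C=C(\C)CO`) gives > 52000 nM and this too is only a limit. Compound 3 (`C=C[C@@](C)(/C=C/c1ccc(O)cc1)CC/C=C(\C)C(=O)OCC`) has not yet been measured. It carries ethoxycarbonyl in place of hydroxymethyl on a double-bonded chain carbon bound to a double-bonded chain carbon and a saturated chain carbon. For the measured compounds named here, the one measured step that bears on this change is a step that the two limits leave unreadable from compound 1 to compound 2 and it offers no size to carry over. Both measured compounds share the same limit (the limit of > 52000 nM in this assay, at which 2 of the 2 values shown sit). With no readable step to lean on, no shift beyond the scatter is expected in this assay and the estimated step is a number no higher from compound 2 to compound 3 (the limit leaves the size open) for now. For compound 3 the expected value is 52000 nM with an estimated range from 20000 nM to 100000 nM and the assay may well report only a limit again.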

Compound 3, half-maximal effective concentration: > 52000 nM
Compound 3: only a limit was reported (the forecaster's own chance of this, stated with the estimate: 75%); the middle value sits exactly at the limit.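

No step among compound 1, compound 2 and compound 3 can be read in this assay, because each result is only a limit: the limit of > 52000 nM in this assay, at which 3 of the 3 values shown sit.

The compounds shown leave open how formyl, hydroxymethyl and ethoxycarbonyl truly compare in this assay, and whether any change would give a readable number.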